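Aryl swap on a triazole: compound 2 to compound 3

A few compounds are considered here, and "the series" means these few. Any claim that something is new, unique, unknown or untested is made for them only; others in the source may bear on it.

Measured so far:
compound 1 `N#CC1=C(N)Oc2c(c3nc4ccccc4nc3c3ccccc23)C12C(=O)N(Cc1cnnn1-c1ccc(Cl)c(Cl)c1)c1ccccc12`: > 50000 nM
compound 2 `N#CC1=C(N)Oc2c(N)cc3nc4ccccc4nc3c2C12C(=O)N(Cc1cnnn1-c1cccc(Br)c1)c1ccccc12`: 18900 nM

Among the measured compounds shown here, in a functional assay on A549 cells (Homo sapiens) for antiproliferative activity, read by MTT assay, with a stated time of 48 h (a higher number here means a weaker inhibitor, a lower number a stronger inhibitor), compound 2 gives 18900 nM, the one plain number among the results. For compound 1 the result is the limit of > 50000 nM in this assay, at which 1 of the 2 values shown sits, a limit of the assay rather than a number. Compound 3 `Cc1ccc(Cl)cc1-n1nncc1CN1C(=O)C2(C(C#N)=C(N)Oc3c(N)cc4nc5ccccc5nc4c32)c2ccccc21` has not yet been measured. It differs from compound 2 in one place (5-chloro-2-methylphenyl in place of 3-bromophenyl on an aromatic nitrogen). For the measured compounds named here, no measured pair shows what such a change does, so the expected step of a 1.1-fold higher number from compound 2 to compound 3 (0.02 log units; within the scatter) is small, with no direction beyond the usual scatter. Compound 3 is therefore estimated at 20000 nM, with a range from 7000 nM to 60000 nM.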

Compound 3, half-maximal inhibitory concentration: > 50000 nM
Compound 3: only a limit was reported; the forecaster's own chance of this, stated with the estimate: 25%; middle value at least 2.5-fold (0.39 log units) from the limit.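

This gives the first measured sign that the aryl group on this aromatic nitrogen matters: in this assay, 5-chloro-2-methylphenyl in place of 3-bromophenyl gives an at least 2.6-fold higher number from compound 2 to compound 3 (0.42 log units; beyond the scatter), so the change weakens the compound. Compound 3 gives only a limit of the assay, not a number, as compound 1 does: the limit of > 50000 nM in this assay, at which 2 of the 3 values shown sit.

As far as these compounds go, this single pair cannot separate the effect of the chlorine from that of the methyl group, and the full size of the step remains unknown. From the compounds shown here alone, how a plain phenyl or a methoxyphenyl group would fare here also remains open.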